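Swapping fluoro for trifluoromethyl on the amide aryl ring

A few compounds are considered here, and "the series" means these few. Any claim that something is new, unique, unknown or untested is made for them only; others in the source may bear on it.

Three measured compounds share one core and differ only in the aryl group attached to the amide nitrogen. In a functional assay on HEK293 cells for agonist activity at D(4) dopamine receptor (Homo sapiens), read by FLIPR (a lower number here means that less compound is needed, a higher number that more compound is needed for the effect), compound 1 `CSc1cccc(NC(=O)CN2CCC(c3cccc[n+]3[O-])CC2)c1` gives 100 nM. Compound 2 `O=C(CN1CCC(c2cccc[n+]2[O-])CC1)Nc1ccc(F)cc1F` gives 103 nM, and compound 3 `Cc1ccc(Cl)cc1NC(=O)CN1CCC(c2cccc[n+]2[O-])CC1` gives 126 nM. Compound 2 thus sits alongside the other two: the step of a 1.0-fold higher number from compound 1 to compound 2 (0.01 log units; within the scatter) and the step of a 1.2-fold higher number from compound 2 to compound 3 (0.09 log units; within the scatter) both fall within the scatter, as does a 1.3-fold higher number from compound 1 to compound 3 (0.10 log units; within the scatter), so no ranking among the three can be read from these numbers.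

Compound 4 `O=C(CN1CCC(c2cccc[n+]2[O-])CC1)Nc1ccc(F)cc1C(F)(F)F` has not been measured. It differs from compound 2 by trifluoromethyl in place of fluoro on an aromatic carbon. For the measured compounds named here, no measured step exchanges exactly these two groups, but each of the three measured steps changes the substituents on the same aryl ring, and none of them moves the number beyond the scatter. The step is therefore expected to be a 1.2-fold higher number from compound 2 to compound 4 (0.07 log units; within the scatter), with no clear direction. Compound 4 is expected to give 120 nM in this assay, within a range from 50 nM to 300 nM.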

Compound 4, half-maximal effective concentration: 473 nM
For compound 4 the middle estimate is 3.9-fold (0.60 log units) below the measured one; measured number outside the range, above it.
By their numbers in this assay, from the lowest: compounds 1, 2 and 3 (each within the scatter of the next); then compound 4.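

Until this point, no change on the amide aryl ring had moved the number in this assay beyond the scatter, so the ring seemed to tolerate substitution freely. Trifluoromethyl in place of fluoro, on the carbon ortho to a large group and meta to a fluoro group, gives a 4.6-fold higher number from compound 2 to compound 4 (0.66 log units; beyond the scatter), showing that more compound is needed once this one group is exchanged. Nothing available here accounts for that shift.

Going by these compounds, with a single exchange at this carbon, it remains open whether the number follows the count of heavy atoms in the group or something particular to trifluoromethyl. A nitrile or a methoxy group on the same carbon could show whether other groups keep the number close to that of compound 2 or raise it as well.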